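Furan-2-yl to thiophen-2-yl on the shared core

A few compounds are considered here, and "the series" means these few. Any claim that something is new, unique, unknown or untested is made for them only; others in the source may bear on it.

Values in a functional assay on A-431 cells (Homo sapiens) for cytotoxicity; on this read-out lower numbers stand for an effect already at smaller amounts and higher numbers for an effect only at larger amounts of compound:
Compound 1 `COC1=C(C)C(=O)/C(=C(O)/C=C/c2ccc(Br)cc2)C(=O)C1(C)C` gives 9 ug/mL
Compound 2 `COC1=C(C)C(=O)/C(=C(O)/C=C/c2cc(C)cc(C)c2)C(=O)C1(C)C` gives 4 ug/mL
Compound 3 `COC1=C(C)C(=O)/C(=C(O)/C=C/c2ccco2)C(=O)C1(C)C` gives 14.7 ug/mL

Compound 3 does not separate from compound 1, with a 1.6-fold higher number from compound 1 to compound 3 (0.21 log units; within the scatter). It stands apart only from compound 2, with a 3.7-fold higher number from compound 2 to compound 3 (0.57 log units; beyond the scatter).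

Compound 4 `COC1=C(C)C(=O)/C(=C(O)/C=C/c2cccs2)C(=O)C1(C)C` has not yet been measured in this assay. It carries thiophen-2-yl in place of furan-2-yl on a double-bonded chain carbon bound to a double-bonded chain carbon.

Within the data shown here, no measured step makes this exchange directly. The three measured steps all change the group at this same place, and the largest is the modest one to compound 3 from compound 2. The other beyond the scatter is a 2.3-fold lower number from compound 1 to compound 2 (0.35 log units; beyond the scatter). A small change is therefore expected, with only a slight lean towards a lower number, resting on compound 2 at 4 ug/mL. The expected move, which would stay within the scatter, is a 1.3-fold lower number from compound 3 to compound 4 (0.13 log units; within the scatter). For compound 4 the estimated value is 11 ug/mL, with an expected range of 5.5 ug/mL to 22 ug/mL.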

Compound 4, concentration for half-maximal effect: 10.8 ug/mL
Estimate against measurement, compound 4: 1.0-fold (0.01 log units) above, and the stated range covers the measured number.
By their numbers in this assay, from the lowest: compound 2; then compounds 1, 4 and 3 (each within the scatter of the next).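

In this assay, the exchange of the ring oxygen for sulfur gives a 1.4-fold lower number from compound 3 to compound 4 (0.13 log units; within the scatter), so furan-2-yl and thiophen-2-yl do not separate at this place on a double-bonded chain carbon. Thiophen-2-yl also stays level with 4-bromophenyl, with a 1.2-fold higher number from compound 1 to compound 4 (0.08 log units; within the scatter), while a 2.7-fold higher number from compound 2 to compound 4 (0.43 log units; beyond the scatter) shows that compound 2 stands apart from this new compound as well, leaving 3,5-dimethylphenyl as the only group of the four that separates from all the others. No accompanying measurement bears on why these numbers fall as they do.

From the compounds shown here alone, whether any group at this place can give a lower number than compound 2 at 4 ug/mL remains open. The compounds shown carry only aromatic rings here, so the effect of a cyclohexyl ring, an amine or a carboxylic acid at this place is also unknown.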